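The source may report more compounds than this note shows. Statements on the series, on what has been measured and on what is new or still open speak of the compounds shown alone.

Measured so far in a functional assay on HCC1806 cells (Homo sapiens) for inhibition, read by sulforhodamine B assay, tested at 10 uM; a higher number here means more inhibition at the concentration tested (going by the name of the read-out), a lower number less inhibition:
Compound 1 `CN1CCN(c2ccc(C3=NNC(c4ccc(N(C)C)cc4)C3)cc2)CC1`: 31.2%
Compound 2 `CN(C)c1ccc(C2CC(c3ccc(-n4cncn4)cc3)=NN2)cc1`: 6.8%
Compound 3 `CC(=O)N1N=C(c2ccc(N3CCN(C)CC3)cc2)CC1c1ccc(N(C)C)cc1`: -0.8%

Compound 3 sits at the bottom of these three numbers. Its gap to compound 2 is within the scatter, while compound 1 lies beyond the scatter above it, the step being a number 32 percentage points lower from compound 1 to compound 3 (beyond the scatter). Compound 4 `CN1CCN(c2ccc(C3=NN(C(=O)CCCl)C(c4ccc(N(C)C)cc4)C3)cc2)CC1` differs from compound 3 by chloromethyl in place of hydrogen on a saturated chain carbon bound to a carbonyl carbon. Going by the values given here, the only measured step touching this part of the molecule is a number 32 percentage points lower from compound 1 to compound 3 (beyond the scatter), which concerns the acetyl entering; the step of a number 24.4 percentage points lower from compound 1 to compound 2 (beyond the scatter) concerns another position and does not bear on it. Among the compounds with values here, no measured pair shows hydrogen replaced by chloromethyl on a saturated chain carbon bound to a carbonyl carbon. Compound 4 is therefore expected to stay close to compound 3, with a number 3.8 percentage points higher from compound 3 to compound 4 (within the scatter) lying within the scatter. The estimate for compound 4 in this assay is 3%, ranging from -12% to 20%.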

Compound 4, a percentage reported as inhibition, at one concentration (the size of the read-out at that concentration, not a potency): 1.7%
Beside the measured number, compound 4's estimate is 1.3 percentage points above it; the measured number falls inside the stated range.
By their numbers in this assay, from the lowest: compounds 3, 4 and 2 (each within the scatter of the next); then compound 1.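

In this assay, the acetyl of compound 3 and the (2-chloroethyl)carbonyl of compound 4 cannot be told apart on the amine nitrogen in the ring (a number 2.5 percentage points higher from compound 3 to compound 4 (within the scatter)). The drop seen on acylating that nitrogen is therefore not limited to acetyl, as the second acyl group also gives a step beyond the scatter (a number 29.5 percentage points lower from compound 1 to compound 4 (beyond the scatter)). No measured evidence accounts for this result. Still open, as far as these compounds go, is whether an ethyl on that nitrogen, or an acyl chain ending in an amine or a carboxylic acid, would stay nearer compound 1.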